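The source may report more compounds than this note shows. Statements on the series, on what has been measured and on what is new or still open speak of the compounds shown alone.

Compound 1 `CCCOc1nc(C(C)(C)C)ccc1CNC(=O)C(C)c1ccc(NS(C)(=O)=O)c(F)c1` is one of three closely related compounds that were tested in an assay on cells for antagonist activity at transient receptor potential cation channel subfamily V member 1 (Homo sapiens), read by FLIPR and calcium flux, with a stated time of 6 min; a higher number here means a weaker inhibitor, a lower number a stronger inhibitor. Compound 1 gives 1.7 nM, the second highest of the three numbers. Compound 2 `CCCCCCOc1nc(C(C)(C)C)ccc1CNC(=O)C(C)c1ccc(NS(C)(=O)=O)c(F)c1` gives 2.7 nM, and compound 3 `CC(C)CCOc1nc(C(C)(C)C)ccc1CNC(=O)C(C)c1ccc(NS(C)(=O)=O)c(F)c1` gives 0.8 nM. Compound 4 `COCCCOc1nc(C(C)(C)C)ccc1CNC(=O)C(C)c1ccc(NS(C)(=O)=O)c(F)c1` has not yet been measured. It differs from compound 1 by methoxy in place of hydrogen on a saturated chain carbon, three bonds along the chain from an oxygen on an aromatic ring. The step that bears most on this change is a 1.6-fold higher number from compound 1 to compound 2 (0.20 log units; within the scatter), which also adds to the same saturated chain carbon and stays within the scatter. The step of a 2.1-fold lower number from compound 1 to compound 3 (0.33 log units; beyond the scatter) is modest and changes the chain closer to the ring oxygen. Little change beyond the scatter is therefore expected in this assay. The expected step is a 1.5-fold higher number from compound 1 to compound 4 (0.17 log units; within the scatter). Compound 4 is estimated at 2.5 nM, with a range from 1 nM to 6 nM.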

Compound 4, inhibition constant: 5.6 nM
Beside the measured number, compound 4's estimate is 2.2-fold (0.35 log units) below it; the measured number falls inside the stated range.
By their numbers in this assay, from the lowest: compound 3; then compounds 1 and 2 (each within the scatter of the next); then compound 4.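

Unlike the propyl of compound 2, methoxy on this saturated chain carbon gives a 3.3-fold higher number from compound 1 to compound 4 (0.52 log units; beyond the scatter) in this assay, so what enters here matters and not only its presence. The methoxy chain also gives a 2.1-fold higher number from compound 2 to compound 4 (0.32 log units; beyond the scatter) and a 7.0-fold higher number from compound 3 to compound 4 (0.85 log units; beyond the scatter) when set against the all-carbon chains. Nothing available explains this rise.

From the compounds shown here alone, whether an amine or a hydroxyl on the same carbon would give a number like that of compound 4 remains open. So does whether a longer chain carrying methoxy would do the same.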